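The source may report more compounds than this note shows. Statements on the series, on what has been measured and on what is new or still open speak of the compounds shown alone.

Two fluorinated acrylamides share a bicyclic core and both reach the ceiling of the read-out. Compound 1 `O=C(/C=C1\CCc2cc(F)cc(F)c21)NC1CC1` carries a cyclopropyl group on its amide nitrogen, and in a functional assay on the whole organism with Mus musculus as the target, at a dose of 100 mg/kg by the intraperitoneal route (a higher number here means more inhibition at the dose given (going by the name of the read-out), a lower number less inhibition), compound 1 gives 100%. Compound 2 `NC(=O)/C=C1\CCc2c(F)cc(F)cc21` has an unsubstituted amide; in this assay compound 2 gives 100%, level with compound 1 at the digits shown and within the usual scatter of it. Compound 3 `CC(C)NC(=O)/C=C1\CCc2c(F)cc(F)cc21` is the next member: the difference from compound 2 is isopropyl in place of hydrogen on an amide-type nitrogen. Within the data shown here, no measured pair shows this particular change, so its size cannot be read from the data. Since compound 1 already gives 100% with a carbon substituent on the amide nitrogen, and compound 2 gives 100%, a step from compound 2 to compound 3 of a number 5 percentage points lower from compound 2 to compound 3 (within the scatter) is expected, that is, none beyond the scatter. Compound 3 is therefore estimated at 95%, within a range of 75% to 100%.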

Compound 3, a percentage reported as inhibition, in the whole organism at one dose (the size of the read-out at that dose, not a potency): 100%
The estimate for compound 3 lay 5 percentage points below the measured number, and the stated range covers the measured number.
By their numbers in this assay, from the lowest: compounds 1, 2 and 3 (each within the scatter of the next).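

Among these compounds, the step of no change at the digits printed from compound 2 to compound 3 (within the scatter) in this assay is the first reading at this one place, and it comes from two compounds that share the same core and the same fluorine pattern. It shows that isopropyl can stand in place of hydrogen on the amide-type nitrogen without the read-out moving beyond the scatter at this dose. Compound 2 and compound 3 both sit at the top of the read-out, which hides any gain from isopropyl, and no measurement here gives a reason for the result.

Open, on these data alone, is whether a longer chain, an amine or a carboxylic acid on this nitrogen would hold the same level. Also open, as far as these compounds go, is whether compound 2 and compound 3 would stay level at a lower dose.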